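The source may hold more compounds than are shown below. What is called first, only, known or untested is meant among the compounds shown, and "the series" means these compounds.

Compound 3, `Cc1cc(C)nc(SCC(=O)[C@H](CC(=O)O)NC(=O)[C@@H](NC(=O)COc2cccc3ccccc23)C(C)C)n1`, belongs to a small set sharing one core. In a functional assay on Jurkat cells (Homo sapiens) for inhibition (a higher number here means a weaker inhibitor, a lower number a stronger inhibitor), compound 1, `CC(C)[C@H](NC(=O)COc1cccc2ccccc12)C(=O)N[C@@H](CC(=O)O)C(=O)CSc1nccn1C`, gives only a limit, > 200000 nM. Compound 2, `CC(C)[C@H](NC(=O)COc1cccc2ccccc12)C(=O)N[C@@H](CC(=O)O)C(=O)CSc1nc2ccccc2s1`, likewise gives a limit in this assay, > 200000 nM. From the compounds shown here alone, compound 3 itself also sits at a limit in this assay, > 200000 nM, so its standing on the numbers is unknown beyond (the limit of > 200000 nM in this assay, at which 3 of the 3 values shown sit). The steps a step that the two limits leave unreadable from compound 1 to compound 2, a step that the two limits leave unreadable from compound 1 to compound 3 and a step that the two limits leave unreadable from compound 2 to compound 3 are therefore of unreadable size. Compound 4, `CC(C)[C@H](NC(=O)COc1cccc2ccccc12)C(=O)N[C@@H](CC(=O)O)C(=O)COc1ccnc(C(F)(F)F)n1`, differs from compound 3 by (2-(trifluoromethyl)pyrimidin-4-yl)oxy in place of (4,6-dimethylpyrimidin-2-yl)sulfanyl on a saturated chain carbon bound to a carbonyl carbon. Going by the values given here, none of the measured steps bear on this change with a readable size, so for compound 4 in this assay a value around 100000 nM is expected, between 5000 nM and 300000 nM, the step of an at least 2.0-fold lower number from compound 3 to compound 4 (0.30 log units; that floor lies within the scatter) being an estimate only.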

Compound 4, half-maximal inhibitory concentration: 37000 nM
Beside the measured number, compound 4's estimate is 2.7-fold (0.43 log units) above it; the measured number falls inside the stated range.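

In this assay, the (2-(trifluoromethyl)pyrimidin-4-yl)oxy group on a saturated chain carbon bound to a carbonyl carbon gives the first readable gain at this position, with an at least 5.4-fold lower number from compound 3 to compound 4 (0.73 log units; beyond the scatter). The same holds against the other sulfur-linked groups, with an at least 5.4-fold lower number from compound 2 to compound 4 (0.73 log units; beyond the scatter) and an at least 5.4-fold lower number from compound 1 to compound 4 (0.73 log units; beyond the scatter). The steps among compound 1, compound 2 and compound 3 cannot be read, because all three sit at one limit: the limit of > 200000 nM in this assay, at which 3 of the 4 values shown sit.

The compounds shown do not separate the exchange of sulfur for oxygen from the change of ring substituents. From the compounds shown here alone, how a (4,6-dimethylpyrimidin-2-yl)oxy or a plain phenoxy group would read in this assay remains open.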